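A few compounds are considered here, and "the series" means these few. Any claim that something is new, unique, unknown or untested is made for them only; others in the source may bear on it.

Series notes. Compound 3 `COc1ccc(C(=O)/C=C/c2cc(-c3cc(OC)c(OC)c(OC)c3)n[nH]2)cc1OC` stands alongside compound 1 `COc1cc(-c2cc(/C=C/C(=O)c3ccc(N)cc3)[nH]n2)cc(OC)c1OC` and compound 2 `COc1cc(-c2cc(/C=C/C(=O)c3ccc(Cl)c(Cl)c3)[nH]n2)cc(OC)c1OC` in a functional assay on HCC 2998 cells (Homo sapiens) for cytotoxicity, read by sulforhodamine B assay, with a stated time of 48 h, tested at 10 uM; on this read-out lower numbers stand for a stronger effect and higher numbers for a weaker effect at the one concentration tested. In this assay compound 3 gives -85%, compound 1 gives -86% and compound 2 gives 49%. Compound 3 holds the second highest of the three numbers: its nearest neighbour is compound 1, with a number 1 percentage points higher from compound 1 to compound 3 (within the scatter), and its furthest is compound 2, with a number 134 percentage points lower from compound 2 to compound 3 (beyond the scatter). The remaining step is a number 135 percentage points higher from compound 1 to compound 2 (beyond the scatter).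

The next compound is compound 4 `COc1ccc(C(=O)/C=C/c2cc(-c3cc(OC)c(OC)c(OC)c3)n[nH]2)cc1`. Relative to compound 3 the change is hydrogen in place of methoxy on an aromatic carbon; cut one bond further out it reads 3,4-dimethoxyphenyl to 4-methoxyphenyl, so it sits on the aryl attached to the carbonyl carbon, the same place every measured step touches. Those steps span both sizes: 3,4-dimethoxyphenyl and 4-aminophenyl give numbers within the scatter of each other, while 3,4-dichlorophenyl moves the number a long way. Removing a single methoxy is a smaller change than any measured swap. The expectation for compound 4 is therefore a step of a number 20 percentage points higher from compound 3 to compound 4 (beyond the scatter) in this assay, a number staying strongly negative. The result for compound 2 is a reminder that a larger upward movement cannot be excluded. Compound 4 is estimated at -65%, between -95% and 10%.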

Compound 4, a percentage reported as activity, at one concentration (the size of the read-out at that concentration, not a potency): -83%
Compound 4: the middle estimate sits 18 percentage points above what was measured; the measured number falls inside the stated range.
By their numbers in this assay, from the lowest: compounds 1, 3 and 4 (each within the scatter of the next); then compound 2.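

In this assay hydrogen in place of methoxy on an aromatic carbon gives a number 2 percentage points higher from compound 3 to compound 4 (within the scatter), so a single methoxy on the aryl attached to the carbonyl carbon suffices for a read-out matching that of the 3,4-dimethoxyphenyl compound. The 4-methoxyphenyl group also matches the 4-aminophenyl group (a number 3 percentage points higher from compound 1 to compound 4 (within the scatter)) and stands far from the 3,4-dichlorophenyl group (a number 132 percentage points lower from compound 2 to compound 4 (beyond the scatter)), which makes compound 2 the only exception to the shared read-out among the compounds shown. Nothing measured here bears on why the read-outs fall this way.

Still open, as far as these compounds go, is whether the gap belongs to the chlorines themselves or to the absence of a methoxy or amino group, which a 4-chlorophenyl or an unsubstituted phenyl on the carbonyl carbon would help to separate. Also open, from the compounds shown here alone, is how far this aryl tolerates other groups, such as a carboxylic acid or a dimethylamino group in place of the methoxy of compound 4, and whether the matching compounds would still match across a range of concentrations rather than at the single one tested.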